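Ethoxy to methoxy on the shared core

This account rests on a few compounds, and the source may have more. Where it says the series, first, only, none or still open, it means among the compounds named here.

Compound 2 `CCOc1nc(N)c2nc(O)n(Cc3ccccc3)c2n1` stands lowest of the two numbers in hand. In a functional assay (spleen, spleen) for activation, with Mus musculus as the target (a lower number here means that less compound is needed, a higher number that more compound is needed for the effect), compound 2 gives 0.1 uM. The nearest number belongs to compound 1 `Cc1ccc(Cn2c(O)nc3c(N)ncnc32)cc1`, which in this assay gives 10 uM; that gap is beyond the scatter, but compound 1 differs from compound 2 in more than one place, so no single step can be read from the pair. Compound 3 `COc1nc(N)c2nc(O)n(Cc3ccccc3)c2n1` has not been measured in this assay. It differs from compound 2 by hydrogen in place of methyl on a saturated chain carbon bound to an oxygen on an aromatic ring. Among the compounds with values here, the change is the shortening of ethoxy to methoxy; no measured pair shows this step, so its direction is open. The step from the ethoxy to the methoxy compound is expected to stay within the scatter or lean slightly toward a higher number, a 2.0-fold higher number from compound 2 to compound 3 (0.30 log units; within the scatter). Compound 3 is therefore expected to give about 0.2 uM in this assay, within 0.05 uM to 1 uM.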

Compound 3, minimum effective concentration: 0.1 uM
Estimate against measurement, compound 3: 2.0-fold (0.30 log units) above, and the stated range covers the measured number.
By their numbers in this assay, from the lowest: compounds 2 and 3 (each within the scatter of the next); then compound 1.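

In this assay, within the data shown here, the shortening of ethoxy to methoxy gives no change at the digits printed from compound 2 to compound 3 (within the scatter), the first reading of a single change at this position. On a saturated chain carbon bound to an oxygen on an aromatic ring, methyl and hydrogen are therefore not told apart by this read-out, and the low number of the pair does not depend on the terminal methyl of ethoxy.

Among these compounds, compound 1 differs from compound 2 and compound 3 in more than one place, so no step to it can be read, and what the alkoxy group itself contributes stays open. On these data alone, whether a longer chain such as propoxy, or an amine in place of the ether oxygen, would keep the number also remains open. No measurement at hand offers an explanation for this result.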